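The source may hold more compounds than are shown below. What is called first, only, known or untested is meant among the compounds shown, and "the series" means these compounds.

Measured so far:
compound 1 `CC(=O)c1ccc2c(c1)C1CNCC2C1` with 0.17 nM
compound 2 `CCCCn1cnc2cc3c(cc21)C1CNCC3C1` with 0.2 nM

Both compounds were tested in an assay on HEK293 cells for binding affinity to Neuronal acetylcholine receptor; alpha4/beta2 (Homo sapiens); a higher number here means a weaker inhibitor, a lower number a stronger inhibitor. Compound 1 gives 0.17 nM and compound 2 gives 0.2 nM; these two numbers sit within the scatter of each other, so neither can be called the stronger of the pair. Compound 1 therefore stands at the lowest number of the two, but only by a gap too small to mean anything.

The next compound is compound 3 `FC(F)(F)c1ccc2c(c1)C1CNCC2C1`, which is yet to be measured in this assay. It differs from compound 1 in a single place: trifluoromethyl in place of acetyl on an aromatic carbon. Within the data shown here, nothing among the measured compounds shows what this particular swap does here, since compound 2 differs from compound 1 in a different way. Among the measured compounds shown here, with no comparable step to lean on, the expectation is a moderate step from compound 1 to compound 3, towards a higher number, estimated as a 5.9-fold higher number from compound 1 to compound 3 (0.77 log units; beyond the scatter). Compound 3 is thus expected to give about 1 nM in this assay, with a wide range from 0.2 nM to 6 nM.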

Compound 3, inhibition constant: 0.33 nM
Estimate against measurement, compound 3: 3.0-fold (0.48 log units) above; the measured number falls inside the stated range.
By their numbers in this assay, from the lowest: compounds 1, 2 and 3 (each within the scatter of the next).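

In this assay trifluoromethyl in place of acetyl on this aromatic carbon gives a 1.9-fold higher number from compound 1 to compound 3 (0.29 log units; within the scatter) and so the two groups cannot be told apart at this position of the shared core. The pair also shows that a group without a carbonyl can stand here and leave the number within the scatter: acetyl counts 1 hydrogen-bond acceptor and trifluoromethyl counts 0, so for this one pair that acceptor is not needed to keep the number where it is. Nothing available explains why the two groups match, so this remains an observation about compound 1 and compound 3 alone.

On these data alone, whether the position accepts any group or only some remains open, for instance whether an amine, a carboxylic acid or a longer chain on the same aromatic carbon would also stay within the scatter of compound 1. Also open, as far as these compounds go, is whether the same swap would behave this way on a different core, such as that of compound 2, where a one-place comparison is not yet available.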